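A few compounds are considered here, and "the series" means these few. Any claim that something is new, unique, unknown or untested is made for them only; others in the source may bear on it.

Three measured compounds share one core and differ only in the group on the triazole nitrogen. Compound 1 `COc1ccc(-n2cc(CN3C(=O)C[C@@H]4CC[C@@]3(C)C4(C)C)nn2)cc1` gives 70 nM in a functional assay on LoVo cells (Homo sapiens) for inhibition, read by MTT assay, with a stated time of 24 h; a higher number here means a weaker inhibitor, a lower number a stronger inhibitor. Compound 2 `CC1(C)[C@H]2CC[C@]1(C)N(Cc1cn(-c3ccccc3C#N)nn1)C(=O)C2` gives 140 nM in this assay, and compound 3 `CC1(C)[C@H]2CC[C@]1(C)N(Cc1cn(-c3cccc(O)c3)nn1)C(=O)C2` gives 410 nM. Compound 3 therefore carries the highest number of the three: a 5.9-fold higher number from compound 1 to compound 3 (0.77 log units; beyond the scatter), and a 2.9-fold higher number from compound 2 to compound 3 (0.47 log units; beyond the scatter), whereas a 2.0-fold higher number from compound 1 to compound 2 (0.30 log units; within the scatter). Compound 4 `CC1(C)[C@H]2CC[C@]1(C)N(Cc1cn(-c3ccccc3Cl)nn1)C(=O)C2` has not yet been measured and differs from compound 3 in one place: 2-chlorophenyl in place of 3-hydroxyphenyl on an aromatic nitrogen. The step that bears on this change is a 2.9-fold higher number from compound 2 to compound 3 (0.47 log units; beyond the scatter), since compound 2 carries 2-cyanophenyl and compound 4 carries 2-chlorophenyl in the same place. Read in reverse, that step points to a lower number once 3-hydroxyphenyl leaves, of modest size, and the two measured 2-substituted analogues give no reason to expect more. Compound 4 is therefore expected to show a 2.7-fold lower number from compound 3 to compound 4 (0.44 log units; beyond the scatter) in this assay. The estimate for compound 4 is 150 nM, with a range from 60 nM to 400 nM.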

Compound 4, half-maximal inhibitory concentration: 190 nM
The estimate for compound 4 lay 1.3-fold (0.10 log units) below the measured number, and the stated range covers the measured number.
By their numbers in this assay, from the lowest: compounds 1, 2 and 4 (each within the scatter of the next, the first and the last beyond it); then compound 3.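

In this assay, a second 2-substituted phenyl group, 2-chlorophenyl, also stands apart from 3-hydroxyphenyl, with a 2.2-fold lower number from compound 3 to compound 4 (0.33 log units; beyond the scatter), so this difference is not confined to the 2-cyanophenyl compound. Chloro and cyano cannot be told apart on this ring, since a 1.4-fold higher number from compound 2 to compound 4 (0.13 log units; within the scatter), while a 2.7-fold higher number from compound 1 to compound 4 (0.43 log units; beyond the scatter), so 2-chlorophenyl does not match 4-methoxyphenyl at this triazole nitrogen. Nothing among the data shown accounts for these differences.

Between compound 3 and compound 4, both the substituent and its place on the phenyl ring change, so the two cannot be separated; 2-hydroxyphenyl or 3-chlorophenyl would be needed to do so. From the compounds shown here alone, it also remains open how this assay would respond to an amine on the phenyl ring, or to a carboxylic acid there.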